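A few compounds are considered here, and "the series" means these few. Any claim that something is new, unique, unknown or untested is made for them only; others in the source may bear on it.

Compound 1 `O=C(CCCCC1CCSS1)Nc1ccc([N+](=O)[O-])c(C(F)(F)F)c1`: 5.04%
Compound 2 `O=C(CCCCC(S)CCS)Nc1ccc(Cl)cc1`: 1.06%

These two compounds were tested in a functional assay on Bel-7402 cells (Homo sapiens) for inhibition, read by MTT assay, with a stated time of 24 h, tested at 0.1 ug/mL; on this read-out higher numbers stand for more inhibition of growth at the one concentration tested and lower numbers for less inhibition of growth. In this assay compound 2 gives 1.06%, and compound 1 gives 5.04%. These two numbers lie within the usual scatter of each other, so they do not rank the compounds, and both are small on this scale. Among the measured compounds shown here, the two compounds differ in more than one place, so the data hold no measured step for a single change.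

The next compound, compound 3 `COc1ccc(NC(=O)CCCCC(S)CCS)cc1`, keeps the chain of compound 2 and changes one group: methoxy in place of chloro on an aromatic carbon. This puts methoxy in place of chloro on an aromatic carbon, para to a large group. Nothing measured here shows what this replacement does, so no step beyond the scatter is expected, in either direction. Compound 2 stands at 1.06%, and compound 1 stands at 5.04%. These two numbers give no sign of a larger effect. The expected change is a number 2.9 percentage points higher from compound 2 to compound 3 (within the scatter), which would stay within the scatter. For compound 3 the estimated value is 4%, with an expected range from 0% to 14%.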

Compound 3, percent growth inhibition at one concentration: 5.35%
For compound 3 the middle estimate is 1.4 percentage points below the measured one, and the stated range covers the measured number.
By their numbers in this assay, from the lowest: compounds 2, 1 and 3 (each within the scatter of the next).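

Among the compounds shown here, compound 3 gives the first measured step for a single change in this set: putting methoxy in place of chloro on an aromatic carbon, para to a large group, yields a number 4.3 percentage points higher from compound 2 to compound 3 (within the scatter) in this assay at the one concentration tested. This step does not separate the two groups, even though methoxy brings one more heavy atom and a hydrogen-bond acceptor that chloro lacks, so at this position the swap leaves no readable mark on growth inhibition. Nothing available bears on why the two groups cannot be told apart here.

As far as these compounds go, it remains open whether another group at this position, such as an amine or a carboxylic acid, would give a step beyond the scatter, or whether any such group would lift the number well clear of the small values seen so far. From the compounds shown here alone, the effect of the chain alone also remains open, as compound 1 differs from compound 2 and from compound 3 in more than one place, so its chain cannot be compared directly with theirs.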